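The compounds below may be only part of what the source reports. "The series", "measured", "known", "first", "only" and "open" are said of these compounds alone.

Of the compounds shown here, three sharing one core have been measured. Compound 1 `Clc1ccc(-c2cn(Cc3ccccc3)c3c2CNCC3)c(Cl)c1` carries a 2,4-dichlorophenyl group and gives 2070 nM in an assay on HEK293 cells for displacement of a labelled ligand from 5-hydroxytryptamine receptor 7 (Rattus norvegicus), with a stated time of 60 min; a higher number here means a weaker inhibitor, a lower number a stronger inhibitor. Compound 2 `O=[N+]([O-])c1ccc(-c2cn(Cc3ccccc3)c3c2CNCC3)cc1` carries a 4-nitrophenyl group and gives 450 nM in this assay. Compound 3 `Fc1ccc(-c2cn(Cc3ccccc3)c3c2CNCC3)cc1` carries a 4-fluorophenyl group and gives 45 nM in this assay, the lowest of the three numbers: the step of a 46-fold lower number from compound 1 to compound 3 (1.66 log units; beyond the scatter) is large, and the step of a 10-fold lower number from compound 2 to compound 3 (1.00 log units; beyond the scatter) is modest, both beyond the scatter.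

Compound 4 `COc1ccc(-c2cn(Cc3ccccc3)c3c2CNCC3)cc1` differs from compound 3 in one place: methoxy in place of fluoro on an aromatic carbon. Among the measured compounds shown here, no measured step bears directly on this change, since none of the measured compounds carries a methoxy group. What the two steps show is that the fluoro group on this position gives a clearly lower number than either the nitro group or the pair of chloro groups, so another substituent in its place is more likely to raise the number than lower it. The methoxy group brings one hydrogen-bond acceptor where the fluoro group brought none, as the nitro group of compound 2 does. Compound 4 is therefore expected to give a somewhat higher number than compound 3, a step of a 2.9-fold higher number from compound 3 to compound 4 (0.46 log units; beyond the scatter), with an estimated value of 130 nM in this assay, in the range 35 nM to 500 nM.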

Compound 4, inhibition constant: 290 nM
Compound 4: the middle estimate sits 2.2-fold (0.35 log units) below what was measured; the range from low to high includes it.
By their numbers in this assay, from the lowest: compound 3; then compounds 4 and 2 (each within the scatter of the next); then compound 1.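

In this assay, the step of a 6.4-fold higher number from compound 3 to compound 4 (0.81 log units; beyond the scatter) shows that the low number of compound 3 does not carry over to every small group on this aromatic carbon, para to a large group: going from 4-fluorophenyl to 4-methoxyphenyl gives up much of it. The step of a 1.6-fold lower number from compound 2 to compound 4 (0.19 log units; within the scatter) lies within the scatter, so methoxy and nitro cannot be told apart here even though they are quite different groups, while the step of a 7.1-fold lower number from compound 1 to compound 4 (0.85 log units; beyond the scatter) lies beyond the scatter, which keeps the 2,4-dichlorophenyl compound apart from the methoxy compound. Nothing available explains why fluoro stands apart from methoxy and nitro, and the hydrogen-bond acceptor that enters with methoxy cannot be singled out from the change in size.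

The compounds shown leave open where a plain hydrogen, a single chloro, a methyl, a hydroxyl or an amine on this same carbon would fall relative to fluoro. They also leave open whether a second fluoro on this ring would keep the number low.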